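Methyl for hydrogen on the fused ring, second instance

The source may hold more compounds than are shown below. What is called first, only, known or untested is meant among the compounds shown, and "the series" means these compounds.

In an assay on cells for inhibition of matrix metalloproteinase-9 (Homo sapiens), read by fluorescence, with stated times of 15 min and 4 h (a lower number here means a stronger inhibitor, a higher number a weaker inhibitor), compound 2 `O=C(CCc1ccccc1)Nc1cccc(-c2nc3ccccc3[nH]2)c1` gives 68000 nM. Compound 1 `Cc1ccc2nc(-c3cccc(NC(=O)CCc4ccccc4)c3)[nH]c2c1` carries the change methyl in place of hydrogen on an aromatic carbon and in this assay compound 1 gives 26600 nM, so that a 2.6-fold lower number from compound 2 to compound 1 (0.41 log units; beyond the scatter). Compound 3 `O=[N+]([O-])c1ccc(-c2nc3ccccc3o2)cc1` has another core; the difference between the cores of compound 3 and compound 2 is not broken down here. In this assay compound 3 gives 36000 nM, within the scatter of compound 1. Compound 4 `Cc1ccc2oc(-c3ccc([N+](=O)[O-])cc3)nc2c1` is not yet measured and differs from compound 3 by methyl in place of hydrogen on an aromatic carbon, the same change as from compound 2 to compound 1, at the same place. Among the compounds with values here, the expectation for compound 4 rests on the single step of a 2.6-fold lower number from compound 2 to compound 1 (0.41 log units; beyond the scatter), made on a different core, so the range is kept wide. For compound 4 a step of like size, a 2.0-fold lower number from compound 3 to compound 4 (0.30 log units; within the scatter), is expected. Compound 4 is estimated at 18000 nM, between 8000 nM and 40000 nM.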

Compound 4, half-maximal inhibitory concentration: 14900 nM
Compound 4: the middle estimate sits 1.2-fold (0.08 log units) above what was measured, and the stated range covers the measured number.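

In this assay, methyl in place of hydrogen on an aromatic carbon gives a 2.4-fold lower number from compound 3 to compound 4 (0.38 log units; beyond the scatter), and the change carries over from one core to the other with its size kept: the same change on two cores in this assay, a 2.6-fold lower number (0.41 log units; beyond the scatter) from compound 2 to compound 1 and a 2.4-fold lower number (0.38 log units; beyond the scatter) from compound 3 to compound 4, 1.1-fold (0.02 log units) apart, within the scatter of two such steps. This rests on two pairs in a single assay, so it supports transfer between these two cores only and gives no rule for any other core. It also does not show why the step has this size, or whether it would hold with methyl on another carbon of the ring.

Still open, going by these compounds, is whether an ethyl or methoxy group at the same place gives a step of like size. Also open, on these data alone, is whether the methyl step survives when an amine or a carboxylic acid replaces the nitro group of compound 4.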